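The compounds below may be only part of what the source reports. "The series", "measured", "known", "first", "only" and "open" are said of these compounds alone.

Measured compounds in a functional assay on HepG2 cells (Homo sapiens) for antiproliferative activity, with a stated time of 72 h; on this read-out lower numbers stand for an effect already at smaller amounts and higher numbers for an effect only at larger amounts of compound:

compound 1 `C=CCNC(=O)n1c(-c2ccc(OC)cc2)cc(=O)c2c(OC)cc(OC)cc21`: > 20000 nM.
compound 2 `COc1ccc(-c2c(Cl)c(=O)c3c(OC)cc(OC)cc3n2S(=O)(=O)c2ccc(OC)cc2)cc1`: "not determined" (no result reported).
compound 3 `COc1ccc(-c2c(Br)c(=O)c3c(OC)cc(OC)cc3n2S(=O)(=O)c2ccc(OC)cc2)cc1`: > 20000 nM.

The entry for compound 1 is a limit of this assay, not a number: the cells were not measurably affected up to the highest amount tested. The entry for compound 3 is likewise a limit of the same kind. For compound 2 no result was reported, so nothing is known about it. Among the compounds with values here, compound 1 therefore does not stand at any particular place among real numbers; it shares the limit of > 20000 nM in this assay, at which 2 of the 3 values shown sit, with one other compound, and no measured pair differs in a single place, so no step size from the data is available.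

Compound 4 `COc1ccc(-c2cc(=O)c3c(OC)cc(OC)cc3n2S(=O)(=O)c2ccc(F)cc2)cc1` has not been measured. Compared with compound 1 the change is (4-fluorophenyl)sulfonyl in place of allylcarbamoyl on an aromatic nitrogen. Compounds 2 and 3 also carry a sulfonyl group on that nitrogen, and compound 3 sits at the limit, which suggests that a sulfonyl group alone does not bring activity into view. The step from compound 1 to compound 4 is expected to be none beyond the scatter, a step that the limit leaves unreadable from compound 1 to compound 4, with a real chance that only a limit is reported again. Compound 4 is expected to give about 25000 nM, within 5000 nM to 100000 nM.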

Compound 4, half-maximal effective concentration: > 65500 nM
Compound 4 was reported as a limit; the forecaster's own chance of this, stated with the estimate: 70%; middle value at least 2.6-fold (0.41 log units) away from the limit.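

Compound 1 and compound 4 are both reported only as limits, not as numbers, so no step can be read from putting (4-fluorophenyl)sulfonyl in place of allylcarbamoyl on the aromatic nitrogen. The compounds shown leave open whether in this assay any group on that nitrogen gives a measurable value.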